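The source may report more compounds than this note shows. Statements on the series, on what has been measured and on what is new or still open speak of the compounds shown alone.

Measured compounds:
- Compound 1 `CCn1c(C(=O)NCCC(=O)OC)ccc1C(CC)(CC)c1ccc(C#CC(O)(CC)CC)c(C)c1`: in an assay on cells for agonist activity at vitamin D3 receptor (Homo sapiens), read by microscopy (a higher number here means that more compound is needed for the effect, a lower number that less compound is needed), compound 1 reaches only the assay limit, > 50 nM.
- Compound 2 `C#CCCOC(=O)c1ccc(C(CC)(CC)c2ccc(C#CC(O)(CC)CC)c(C)c2)n1CC`: in this assay compound 2 likewise stops at the limit, > 50 nM.
- Compound 3 `CCCCC(=O)c1ccc(C(CC)(CC)c2ccc(C#CC(O)(CC)CC)c(C)c2)n1CC`: in this assay compound 3 also gives only the limit, > 50 nM.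

Compound 3 thus stands where the other two stand, at the limit of > 50 nM in this assay, at which 3 of the 3 values shown sit, so none of the three values is a number that can be ranked. The step that the two limits leave unreadable from compound 1 to compound 3 and the step that the two limits leave unreadable from compound 2 to compound 3 are both unreadable for the same reason, and the step that the two limits leave unreadable from compound 1 to compound 2 tells no more.

Compound 4 `CCn1c(C(=O)NCCC(=O)O)ccc1C(CC)(CC)c1ccc(C#CC(O)(CC)CC)c(C)c1` differs from compound 3 by (2-carboxyethyl)amino in place of butyl on a carbonyl carbon. Compound 1 carries the methyl ester of this same acid on that carbonyl, and compound 1 too sat at the limit. With every measured step hidden behind the limit, no direction and no size can be read for this assay; the expected step that the limit leaves unreadable from compound 3 to compound 4 is therefore set near nothing, with a wide range. Compound 4 is estimated at 120 nM, between 30 nM and 1500 nM.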

Compound 4, half-maximal effective concentration: 293 nM
Compound 4: middle estimate off by 2.4-fold (0.39 log units), on the low side; the measured number falls inside the stated range.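

Compound 4 gives a real number, but no step from compound 1, compound 2 or compound 3 to compound 4 can be read, because those three compounds stop at a limit: the limit of > 50 nM in this assay, at which 3 of the 4 values shown sit.

On these data alone, what stays open is how much, and in which direction, changing the group on the carbonyl carbon shifts the amount of compound needed.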